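Swapping a Methyl for Chlorine on the Aryl Ring

The source may report more compounds than this note shows. Statements on the series, on what has been measured and on what is new or still open speak of the compounds shown alone.

Compound 1, with structure `Cc1ccc(/C=C2/S/C(=N/c3ccccc3)N(Cc3ccncc3)C2=O)cc1`, was tested in an ADME assay on HEK293 cells (Homo sapiens) for cytotoxicity, read by MTT assay, with a stated time of 48 h (on this read-out lower numbers stand for stronger inhibition and higher numbers for weaker inhibition), where compound 1 gives 49500 nM. Going by the values given here, its single measured relative is compound 2, `COc1cc(/C=C2/S/C(=N/c3ccccc3)N(Cc3ccncc3)C2=O)ccc1O`, which carries a 4-hydroxy-3-methoxyphenyl where compound 1 carries a 4-methylphenyl; in this assay compound 2 gives 67400 nM. Among the compounds with values here, the only measured step, a 1.4-fold higher number from compound 1 to compound 2 (0.13 log units; within the scatter), leaves the two compounds indistinguishable on this read-out. Compound 1 thus holds the lowest of the two numbers shown, although the gap to compound 2 is within the scatter.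

The unmeasured compound 3, `O=C1/C(=C\c2cccc(Cl)c2)S/C(=N/c2ccccc2)N1Cc1ccncc1`, keeps the shared core and differs from compound 1 in one place: 3-chlorophenyl in place of 4-methylphenyl on a double-bonded chain carbon bound to a double-bonded ring carbon. Within the data shown here, the one measured step bears on this change only loosely, since it also exchanged the 4-methylphenyl for another ring and showed nothing beyond the scatter in a 1.4-fold higher number from compound 1 to compound 2 (0.13 log units; within the scatter). With no evidence of a move in either direction, compound 3 is expected to land close to compound 1, with an estimated 50000 nM and a range from 20000 nM to 120000 nM. The expected step is a 1.0-fold higher number from compound 1 to compound 3 (0.00 log units; within the scatter), within the scatter.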

Compound 3, half-maximal inhibitory concentration: 71800 nM
For compound 3 the middle estimate is 1.4-fold (0.16 log units) below the measured one; the range from low to high includes it.
By their numbers in this assay, from the lowest: compounds 1, 2 and 3 (each within the scatter of the next).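

Replacing the 4-methylphenyl with 3-chlorophenyl on the double-bonded chain carbon gives a step that stays inside the scatter in this assay (a 1.5-fold higher number from compound 1 to compound 3 (0.16 log units; within the scatter)), and replacing the 4-hydroxy-3-methoxyphenyl with the same group does too (a 1.1-fold higher number from compound 2 to compound 3 (0.03 log units; within the scatter)). Going by these compounds alone, the earlier pair showed this for only two groups, whereas the position now holds three differently substituted phenyl rings, including one that carries a chlorine, and this read-out cannot tell the three compounds apart. No measurement among these results offers an explanation for how closely these numbers sit together.

From the compounds shown here alone, all three groups at this position are substituted phenyl rings, so it remains open whether a ring carrying an amine or a carboxylic acid would give a number beyond the scatter from compound 1, and the same question applies to a longer chain in place of the ring. Going by these compounds, it is also open whether the chlorine would give a similar number at another place on the ring, since compound 3 shows only the 3-chlorophenyl arrangement.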